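Chalcone series: nitro for tert-butyl on the styryl ring

This account rests on a few compounds, and the source may have more. Where it says the series, first, only, none or still open, it means among the compounds named here.

Compound 2 `CC(C)(C)c1ccc(/C=C/C(=O)c2ccc(OCC(=O)N[C@H]3CCOC3=O)cc2)cc1` gives the lowest number of the two measured in a functional assay on DU-145 cells (Homo sapiens) for antiproliferative activity, read by MTT assay, with a stated time of 72 h (on this read-out higher numbers stand for weaker inhibition and lower numbers for stronger inhibition), 6570 nM; compound 1 `O=C(COc1ccc(C(=O)/C=C/c2ccc(F)cc2)cc1)N[C@H]1CCOC1=O` gives 18800 nM, a step of a 2.9-fold lower number from compound 1 to compound 2 (0.46 log units; beyond the scatter). Compound 3 `O=C(COc1ccc(C(=O)/C=C/c2cccc([N+](=O)[O-])c2)cc1)N[C@H]1CCOC1=O` differs from compound 2 by 3-nitrophenyl in place of 4-(tert-butyl)phenyl on a double-bonded chain carbon bound to a double-bonded chain carbon. Within the data shown here, only that step bears on this change, and it shows the aryl substituent shifting the number beyond the scatter. Compound 3 is therefore expected to return toward compound 1, giving a higher number than compound 2 in this assay, a step of a 2.3-fold higher number from compound 2 to compound 3 (0.36 log units; beyond the scatter). The estimate for compound 3 is 15000 nM, within 5000 nM to 45000 nM.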

Compound 3, half-maximal inhibitory concentration: 41800 nM
Estimate against measurement, compound 3: 2.8-fold (0.45 log units) below; the measured number falls inside the stated range.
By their numbers in this assay, from the lowest: compound 2; then compound 1; then compound 3.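

In this assay, 3-nitrophenyl does not bring the number back to that of the 4-fluorophenyl compound but carries it past it: a 6.4-fold higher number from compound 2 to compound 3 (0.80 log units; beyond the scatter), and a 2.2-fold higher number from compound 1 to compound 3 (0.35 log units; beyond the scatter). Compound 3 therefore gives the highest number of the three, and the order at this place runs from 4-(tert-butyl)phenyl through 4-fluorophenyl to 3-nitrophenyl. Nothing measured here accounts for this order.

Compound 3 changes both the substituent and where it sits on the ring, and these two changes cannot be separated here. As far as these compounds go, how an amine or a methoxy group on this ring would read remains open.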